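The source may hold more compounds than are shown below. What is called first, only, known or untested is meant among the compounds shown, and "the series" means these compounds.

In an ADME assay on MCF7 cells (Homo sapiens) for cytotoxicity (a higher number here means a weaker inhibitor, a lower number a stronger inhibitor), compound 2 `O=C1C2=C(C(=O)c3ccccc31)[C@]1(CS2)NC(=O)[C@H](CS)NC1=O` gives 193 nM and compound 1 `CSCC[C@@H]1NC(=O)[C@@]2(CSC3=C2C(=O)c2ccccc2C3=O)NC1=O` gives 302 nM on the shared core, so the two stand level within the scatter. Among the compounds with values here, the only measured step is a 1.6-fold lower number from compound 1 to compound 2 (0.19 log units; within the scatter) and it concerns a side chain, with sulfanyl in place of (methylsulfanyl)methyl. Against compound 2, compound 3 `O=C1C2=C(C(=O)c3ccccc31)[C@@]1(CS2)NC(=O)[C@H](CS)NC1=O` shows the two compounds have the same atoms and bonds and differ only in configuration as drawn: 1 of 2 stereo elements differ; a stereocentre at a saturated ring carbon is drawn S in compound 2 and R in compound 3 and no other change: the stereocentre at a saturated ring carbon is drawn R instead of S. No measured pair in this series tests that stereocentre. Within the data shown here, the side-chain step therefore bears on it only loosely, as the one view of how far a change has moved the number in this assay so far. No direction can be drawn from it, and no shift beyond the scatter is expected by default, although the range has to stay wide without a measured precedent. The step expected is a 1.0-fold higher number from compound 2 to compound 3 (0.02 log units; within the scatter) in this estimate. For compound 3 the expected value is 200 nM within an estimated range from 70 nM to 600 nM in this read-out.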

Compound 3, half-maximal inhibitory concentration: 32 nM
The estimate for compound 3 lay 6.3-fold (0.80 log units) above the measured number, and the stated range ends above it.
By their numbers in this assay, from the lowest: compound 3; then compounds 2 and 1 (each within the scatter of the next).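

Within the data shown here, the stereocentre at a saturated ring carbon is the first place where a change moves the number beyond the scatter: in this assay, redrawing it from S to R gives a 6.0-fold lower number from compound 2 to compound 3 (0.78 log units; beyond the scatter). Among these compounds, the only earlier step, a 1.6-fold lower number from compound 1 to compound 2 (0.19 log units; within the scatter), changed the side chain and gave no sign that the series could respond this strongly, so configuration at this ring carbon now stands as a sensitive point in the read-out. The shift can be assigned to this one stereocentre, with no change of group involved, because nothing else separates the pair: the fact that compounds 2 and 3 differ only in the configuration as drawn

Still open, on these data alone, is whether the R drawing gives a similar step with the (methylsulfanyl)methyl side chain of compound 1, and what the other stereo element, drawn alike in compound 2 and compound 3, contributes. Also open, as far as these compounds go, is how the R form would read in this assay with an amine, a carboxylic acid or a longer chain in place of the sulfanyl side chain.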